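Capping a Hydroxy Group on a Poorly Stable Compound

A few compounds are considered here, and "the series" means these few. Any claim that something is new, unique, unknown or untested is made for them only; others in the source may bear on it.

Compound 1 `O=C(O)c1cc(-c2cccc(COc3ccc4c(c3)CN(C3CCCC3)C4=O)c2)ccc1O` is the least stable of three compounds tested in an ADME assay on microsomes from liver (Rattus norvegicus) for metabolic stability, read by LC-MS, with a stated time of 1 h, at 37 degrees C, tested at 4 uM (a higher number here means that more of the compound is left, a lower number that less of the compound is left), where compound 1 gives 9%. The two other compounds share neither its core nor its hydroxy group: compound 2 `O=C(O)c1cc(-c2cccc(COc3ccc4c(=O)n(C5CC5)sc4c3)c2)ccc1Cl` gives 86% in this assay and compound 3 `Cn1sc2cc(OCc3cccc(-c4ccc(Cl)c(C(=O)O)c4)c3)ccc2c1=O` gives 84%. Among the compounds with values here, both numbers stand far above that of compound 1, and the one single change recorded among them, a number 2 percentage points lower from compound 2 to compound 3 (within the scatter), touches only a group on the nitrogen of their core and says nothing about the change now in question.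

Compound 4 `COc1ccc(-c2cccc(COc3ccc4c(c3)CN(C3CCCC3)C4=O)c2)cc1C(=O)O` differs from compound 1 in one place: methyl in place of hydrogen on an oxygen on an aromatic ring. Within the data shown here, no measured pair in this set shows what such a change does in this assay, so the only anchor is the low value of compound 1 and the observation that both compounds lacking a hydroxy group sit high. On that slender basis a modest rise is expected rather than a fall, and the step of a number 11 percentage points higher from compound 1 to compound 4 (beyond the scatter) is the estimated size of it. For compound 4 the value expected in this assay is 20%, with a likely range from 5% to 50%.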

Compound 4, percent of the compound remaining: 84%
Compound 4: the middle estimate sits 64 percentage points below what was measured; the measured number lies above the stated range.
By their numbers in this assay, from the lowest: compound 1; then compounds 3, 4 and 2 (each within the scatter of the next).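

In this assay, the step of a number 75 percentage points higher from compound 1 to compound 4 (beyond the scatter) shows that this one position matters greatly: going from hydroxy to methoxy, with a single methyl in place of hydrogen on the oxygen, turns a compound of which little is left into one of which most is left. The earlier compounds shown here could not show this, since those with high numbers differ from compound 1 in more than one place, whereas compound 4 keeps everything else in compound 1 unchanged, so the whole step belongs to this one change. Nothing at hand tells what happens to either compound in the microsomes or explains the size of the step.

The compounds shown leave open whether the methyl itself is needed, or whether an ethyl group or a longer chain on the same oxygen, or an amine in place of the hydroxy, would give a similar number in this assay. They also leave open whether the same change would give a step of this size on a different core.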